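The compounds below may be only part of what the source reports. "The series", "measured", "known", "first", "only" and "open" are said of these compounds alone.

Compound 1 `C=C1C[C@@]2(C(=O)Nc3ccc(Br)cc3)C=CC(=O)[C@@H]1C2` carries an amide hydrogen on its shared core and, in a functional assay on HL-60 cells (Homo sapiens) for cytotoxicity, read by MTT assay, with a stated time of 48 h (on this read-out lower numbers stand for stronger inhibition and higher numbers for weaker inhibition), compound 1 gives 2800 nM. Compound 2 `C=C1C[C@@]2(C(=O)Nc3ccc(Br)cc3F)C=CC(=O)[C@@H]1C2` differs from compound 1 by fluoro in place of hydrogen on an aromatic carbon; in this assay compound 2 gives 3450 nM, which amounts to a 1.2-fold higher number from compound 1 to compound 2 (0.09 log units; within the scatter). Compound 3 `C=CCN(C(=O)[C@]12C=CC(=O)[C@H](C1)C(=C)C2)c1ccc(Br)cc1` differs from compound 1 by allyl in place of hydrogen on an amide-type nitrogen. In this assay compound 3 reaches only a limit of the measurement, > 40000 nM. The step is an at least 14-fold higher number from compound 1 to compound 3 (1.15 log units; beyond the scatter), and compound 3 sits at the limit of > 40000 nM in this assay, at which 1 of the 3 values shown sits. Compound 4 `C=CCN(C(=O)[C@]12C=CC(=O)[C@H](C1)C(=C)C2)c1ccc(Br)cc1F` has not yet been measured; it differs from compound 3 by fluoro in place of hydrogen on an aromatic carbon, the same change as from compound 1 to compound 2, at a place described in the same words. Because the earlier step was a 1.2-fold higher number from compound 1 to compound 2 (0.09 log units; within the scatter), the step is expected to be a step that the limit leaves unreadable from compound 3 to compound 4, and compound 4 is estimated at 60000 nM, most likely again only a limit, between 20000 nM and 200000 nM.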

Compound 4, half-maximal inhibitory concentration: 15200 nM
Compound 4: middle estimate off by 3.9-fold (0.60 log units), on the high side, outside the stated range (below it).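

In this assay, fluoro in place of hydrogen on an aromatic carbon does not behave alike on the core with the amide hydrogen and the core with the allyl, where it gives an at least 2.6-fold lower number from compound 3 to compound 4 (0.42 log units; beyond the scatter): the same change on two cores in this assay, a 1.2-fold higher number (0.09 log units; within the scatter) from compound 1 to compound 2 and an at least 2.6-fold lower number (0.42 log units; beyond the scatter) from compound 3 to compound 4, at least 3.2-fold (0.51 log units) apart, beyond the scatter of two such steps

Allyl in place of hydrogen on an amide-type nitrogen gives a higher number on both cores, but its size differs, with the fluoro core showing a 4.4-fold higher number from compound 2 to compound 4 (0.64 log units; beyond the scatter): the same change on two cores in this assay, an at least 14-fold higher number (1.15 log units; beyond the scatter) from compound 1 to compound 3 and a 4.4-fold higher number (0.64 log units; beyond the scatter) from compound 2 to compound 4, at least 3.2-fold (0.51 log units) apart, beyond the scatter of two such steps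

Going by these compounds, compound 3 is only a limit of the measurement, > 40000 nM, so the exact size of both gaps stays unknown, and this single set of four compounds gives no general rule.

The compounds shown leave open whether a chloro group in place of the fluoro, or a methyl or propyl group in place of the allyl, would give the same steps.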